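The compounds below may be only part of what the source reports. "The series", "measured", "known", "first", "only" and "open" are said of these compounds alone.

Measured so far in an ADME assay on LLC-MK2 cells (Macaca mulatta) for cytotoxicity, read by spectrophotometry and crystal violet staining, with a stated time of 4 days; on this read-out higher numbers stand for lower toxicity in this test and lower numbers for higher toxicity in this test:
- Compound 1 `CC(C)n1ncc2c(C(=O)Nc3cccc(C(N)=O)c3)cc(-c3cccs3)nc21` gives 25000 nM
- Compound 2 `CC(C)n1ncc2c(C(=O)Nc3ncccn3)cc(-c3ccsc3)nc21` gives 50000 nM
- Compound 3 `CC(C)n1ncc2c(C(=O)Nc3ncccn3)cc(-c3cccs3)nc21` gives 75000 nM

Compound 3 cannot be told apart from one measured neighbour (a 1.5-fold higher number from compound 2 to compound 3 (0.18 log units; within the scatter)) but lies clearly above the other (a 3.0-fold higher number from compound 1 to compound 3 (0.48 log units; beyond the scatter)). Compound 4 `CC(C)n1ncc2c(C(=O)N3CCc4cccnc43)cc(-c3cccs3)nc21` has not yet been measured. Its difference from compound 3 is a group of 9 heavy atoms (7 carbon, 2 nitrogen; one five-membered non-aromatic ring with 1 hetero atom, one six-membered aromatic ring with 1 hetero atom) in place of a group of 7 heavy atoms (4 carbon, 3 nitrogen; one six-membered aromatic ring with 2 hetero atoms), on a carbonyl carbon and so the (pyrimidin-2-yl)amino group leaves the carbonyl carbon.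

The step that bears most closely on this change is the modest one on the amide-type nitrogen (a 3.0-fold higher number from compound 1 to compound 3 (0.48 log units; beyond the scatter)), since it too replaces the group attached through that carbonyl carbon. The step on the aromatic carbon (a 1.5-fold higher number from compound 2 to compound 3 (0.18 log units; within the scatter)) lies elsewhere in the molecule, stays within the scatter and offers little guidance. Among the compounds with values here, no measured compound carries a group like the incoming one, so the evidence is thin. A modest step toward a lower number in this assay is expected, no larger than the one on the amide-type nitrogen, and it may not clear the scatter. The estimated step is a 1.9-fold lower number from compound 3 to compound 4 (0.27 log units; within the scatter) (an expectation only). Compound 4 is expected at 40000 nM (estimated range 15000 nM to 90000 nM).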

Compound 4, half-maximal cytotoxic concentration: 50000 nM
Estimate against measurement, compound 4: 1.3-fold (0.10 log units) below; measured number inside the range.
By their numbers in this assay, from the lowest: compounds 1, 2, 4 and 3 (each within the scatter of the next, the first and the last beyond it).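

In this assay, the group on the carbonyl carbon changes from (pyrimidin-2-yl)amino, with 1 hydrogen-bond donor, to a fused two-ring group with 0 hydrogen-bond donors, and the result is a 1.5-fold lower number from compound 3 to compound 4 (0.18 log units; within the scatter). Within the data shown here, compounds 1, 2 and 3 all keep the amide hydrogen, so only compound 4 shows that its loss, together with the change from a single ring to two rings, need not produce a step beyond the scatter in this pair, whereas the one step at this place that clears the scatter remains a 3.0-fold higher number from compound 1 to compound 3 (0.48 log units; beyond the scatter). Nothing measured on these compounds accounts for the result or separates the effect of the lost amide hydrogen from that of the added ring.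

The compounds shown leave open whether a saturated amine such as piperidine or morpholine on the carbonyl carbon, or a carboxylic acid carried on the incoming group, would keep the number in the same range. They also leave open whether the incoming group would give the same result alongside thiophen-3-yl, the other group seen on the aromatic carbon.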